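A few compounds are considered here, and "the series" means these few. Any claim that something is new, unique, unknown or untested is made for them only; others in the source may bear on it.

Compound 1 `CN1CCN(CCCOc2cccc3nc(Nc4ccc(Cl)c(F)c4)ccc23)CC1`: 1840 nM. Compound 2 `CN1CCN(CCCOc2cccc3nc(Nc4ccc(F)c(F)c4)ccc23)CC1`: 3140 nM.

Both numbers come from a functional assay on cells (Panel breast (Carcinoma cell lines), Homo sapiens) for inhibition, read by sulforhodamine B assay, with a stated time of 48 h; on this read-out lower numbers stand for stronger inhibition of growth and higher numbers for weaker inhibition of growth. For the measured compounds named here, of the two, compound 2 gives the highest number, but its only neighbour is compound 1, and a 1.7-fold higher number from compound 1 to compound 2 (0.23 log units; within the scatter), so the two cannot be told apart. Compound 3 `CN1CCN(CCCOc2cccc3nc(Nc4cccc(Cl)c4)ccc23)CC1` is not yet measured; it differs from compound 2 by 3-chlorophenyl in place of 3,4-difluorophenyl on a nitrogen on an aromatic ring. Going by the values given here, no measured pair removes a fluorine as this change does, so the only related step is the halogen swap, which stayed within the scatter. Compound 3 is therefore expected to sit close, with an estimated step of a 1.4-fold lower number from compound 2 to compound 3 (0.15 log units; within the scatter). The estimate for compound 3 is 2200 nM, with a range from 900 nM to 5500 nM.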

Compound 3, concentration for 50% growth inhibition: 1850 nM
Beside the measured number, compound 3's estimate is 1.2-fold (0.08 log units) above it; low and high end bracket the measured number.
By their numbers in this assay, from the lowest: compounds 1, 3 and 2 (each within the scatter of the next).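

Replacing 3,4-difluorophenyl with 3-chlorophenyl on the nitrogen gives a 1.7-fold lower number from compound 2 to compound 3 (0.23 log units; within the scatter) and replacing 4-chloro-3-fluorophenyl with 3-chlorophenyl gives a 1.0-fold higher number from compound 1 to compound 3 (0.00 log units; within the scatter) in this assay. The earlier pair showed only one halogen swapped for another, whereas these steps show that 3-chlorophenyl cannot be told apart from either earlier group. No measurement shown here offers an explanation for this. Still open, from the compounds shown here alone, is whether a group of another kind at this place, such as a methoxy, an amine or a carboxylic acid, would move the number beyond the scatter.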